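Working notes: the 4-methylphenyl swap on compound 3

This account rests on a few compounds, and the source may have more. Where it says the series, first, only, none or still open, it means among the compounds named here.

In a functional assay on HCT-116 cells (Homo sapiens) for antiproliferative activity, read by CellTiter-Glo, with a stated time of 72 h (a higher number here means a weaker inhibitor, a lower number a stronger inhibitor), compound 1 `O=C(NO)c1cccc(/C=C/c2ccnc(-c3ccccc3O)c2)c1` gives 3360 nM, compound 2 `O=C(NO)c1ccc(/C=C/c2ccnc(-c3ccccc3O)c2)cc1` gives 1450 nM and compound 3 `O=C(NO)c1ccc(/C=C/c2ccnc(-c3cccc(CO)c3)c2)cc1` gives 1700 nM. Compound 3 lies within the scatter of both compound 2, its nearest neighbour on these numbers, and compound 1, the furthest from it.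

Compound 4 `Cc1ccc(-c2cc(/C=C/c3ccc(C(=O)NO)cc3)ccn2)cc1` carries 4-methylphenyl in place of 3-(hydroxymethyl)phenyl on an aromatic carbon, next to the ring nitrogen (4-methylphenyl in place of 3-(hydroxymethyl)phenyl on an aromatic carbon). For the measured compounds named here, the only measured step at this carbon is a 1.2-fold higher number from compound 2 to compound 3 (0.07 log units; within the scatter), where 3-(hydroxymethyl)phenyl took the place of 2-hydroxyphenyl. Going by the values given here, no measured compound carries 4-methylphenyl, so that single step is a thin guide and the range stays wide. With that step as the guide, no change beyond the scatter is expected in this assay. The expected step is a 1.1-fold lower number from compound 3 to compound 4 (0.05 log units; within the scatter). Compound 4 is estimated at 1500 nM, with an expected range of 700 nM to 3300 nM.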

Compound 4, half-maximal inhibitory concentration: 2390 nM
Estimate against measurement, compound 4: 1.6-fold (0.20 log units) below; the measured number falls inside the stated range.
By their numbers in this assay, from the lowest: compounds 2, 3, 4 and 1 (each within the scatter of the next, the first and the last beyond it).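

At the aromatic carbon next to the ring nitrogen in this assay, 4-methylphenyl in place of 3-(hydroxymethyl)phenyl gives a 1.4-fold higher number from compound 3 to compound 4 (0.15 log units; within the scatter), and 4-methylphenyl in place of 2-hydroxyphenyl gives a 1.6-fold higher number from compound 2 to compound 4 (0.22 log units; within the scatter). This position therefore now has three different aryl groups within the scatter of one another, and the swap for 3-(hydroxymethyl)phenyl shows that going from 1 hydrogen-bond donor and 1 hydrogen-bond acceptor to 0 of each in this group leaves the number within the scatter. No measurement available here accounts for these small steps.

Going by these compounds, whether an amine, a carboxylic acid or a longer chain on this phenyl ring would move the number beyond the scatter remains open. On these data alone, how 4-methylphenyl behaves on the core of compound 1 also remains open.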